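The compounds below may be only part of what the source reports. "The series", "measured", "known", "first", "only" and "open" are said of these compounds alone.

Measured compounds:
- compound 1, `CCCCCCCC(=O)O[C@H]1[C@H](O)[C@H](n2ccc(N)nc2=O)O[C@@H]1CO`: 0.1 ug/mL
- compound 2, `CCCCCC(=O)OC[C@H]1O[C@@H](n2ccc(N)nc2=O)[C@@H](O)[C@@H]1OC(=O)CCCCC`: 0.07 ug/mL
- compound 3, `CCCCCCCCCC(=O)OC[C@H]1O[C@@H](n2ccc(N)nc2=O)[C@@H](O)[C@@H]1O`: 0.1 ug/mL

The three measured compounds share a common core and differ only in where and how long the ester chains are. In a functional assay on HeLa cells (Homo sapiens) for cytotoxicity, read by cell counting, with a stated time of 48 h (on this read-out higher numbers stand for an effect only at larger amounts of compound and lower numbers for an effect already at smaller amounts), compound 1 gives 0.1 ug/mL. Compound 3, which carries its ester chain elsewhere, gives 0.1 ug/mL; compound 1 and compound 3 stand level at the digits shown, and together they hold the highest numbers among the three, with no change between them beyond the scatter. Compound 2, bearing two ester chains, gives 0.07 ug/mL, a number slightly lower than that of compound 1 but still within the scatter. The three numbers thus lie close together in this assay, whatever the chain placement.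

Compound 4, `CCCCCCCCCCCCCC(=O)O[C@H]1[C@H](O)[C@H](n2ccc(N)nc2=O)O[C@@H]1CO`, has not yet been measured in this assay. It differs from compound 1 by one change: hexyl in place of hydrogen on a saturated chain carbon, seven bonds along the chain from a carbonyl carbon. Going by the values given here, no comparable step between measured compounds is available, so the effect of a longer chain can only be guessed. Given that the three measured compounds sit close together in this assay, compound 4 is expected to stay near compound 1, with a step of a 1.2-fold higher number from compound 1 to compound 4 (0.08 log units; within the scatter) that is expected to be small or none beyond the scatter. For compound 4 the estimated value in this assay is 0.12 ug/mL, within a range of 0.04 ug/mL to 0.4 ug/mL.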

Compound 4, concentration for half-maximal effect: 0.08 ug/mL
Compound 4: middle estimate off by 1.5-fold (0.18 log units), on the high side; measured number inside the range.
By their numbers in this assay, from the lowest: compounds 2, 4, 1 and 3 (each within the scatter of the next).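

In this assay, hexyl in place of hydrogen on a saturated chain carbon, seven bonds along the chain from a carbonyl carbon, gives a 1.3-fold lower number from compound 1 to compound 4 (0.10 log units; within the scatter), so at this position the ester chain of compound 1 takes on this added length with no change beyond the scatter. The earlier compounds shown here could not show this, since no two of them differed in one place only, and the closeness of their numbers said nothing about chain length taken alone. No measurement is at hand that would explain this tolerance of the longer chain.

From the compounds shown here alone, what stays open is whether this tolerance has a limit: a longer chain still, or an amine or a carboxylic acid in place of the hexyl, might or might not leave the number in this range. Going by these compounds, it is also open whether hexyl in place of hydrogen would give so small a step on the ester chains of compound 2 and compound 3, which sit elsewhere on the shared core.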